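Phenoxy to phenylsulfanyl on the shared core

The source may report more compounds than this note shows. Statements on the series, on what has been measured and on what is new or still open speak of the compounds shown alone.

Measured compounds:
- compound 1 `CCOC(=O)c1cnc(-c2cccs2)nc1NN1C(=O)C=C(C)C1=O`: 20 nM
- compound 2 `CCOC(=O)c1cnc(-c2cccc([N+](=O)[O-])c2)nc1NN1C(=O)C=C(C)C1=O`: 7000 nM
- compound 3 `CCOC(=O)c1cnc(Oc2ccccc2)nc1NN1C(=O)C=C(C)C1=O`: 15000 nM

All three carry the same core and differ only in the group on the aromatic carbon between the two ring nitrogen atoms. In a functional assay on Jurkat cells for inhibition of nuclear factor NF-kappa-B complex (Homo sapiens) (on this read-out higher numbers stand for weaker inhibition and lower numbers for stronger inhibition), compound 1 gives 20 nM, compound 2 gives 7000 nM and compound 3 gives 15000 nM. Compound 3 stands at the highest number of the three: a 750-fold higher number from compound 1 to compound 3 (2.88 log units; beyond the scatter) and a 2.1-fold higher number from compound 2 to compound 3 (0.33 log units; beyond the scatter). The change a 350-fold higher number from compound 1 to compound 2 (2.54 log units; beyond the scatter) shows that a change of the group at this position can move the number a long way.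

Compound 4 `CCOC(=O)c1cnc(Sc2ccccc2)nc1NN1C(=O)C=C(C)C1=O` is not yet measured. It differs from compound 3 by phenylsulfanyl in place of phenoxy on an aromatic carbon. Going by the values given here, no measured step exchanges oxygen for sulfur in this linker, so none of the three steps bears directly on it; the measured steps only show that this position is sensitive and that the phenoxy compound sits at the weak end. The estimate for compound 4 therefore stays close to compound 3, with wide room on both sides: compound 4 is expected at 10000 nM, range 2000 nM to 40000 nM, which means an expected 1.5-fold lower number from compound 3 to compound 4 (0.18 log units; within the scatter) in this assay.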

Compound 4, half-maximal inhibitory concentration: 1000 nM
Compound 4: middle estimate off by 10-fold (1.00 log units), on the high side; measured number below the stated range.
By their numbers in this assay, from the lowest: compound 1; then compound 4; then compound 2; then compound 3.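

In this assay, a single atom in the linker is enough to change the result at this position, with the ring and the heavy-atom count of the group unchanged: a 15-fold lower number from compound 3 to compound 4 (1.18 log units; beyond the scatter). The earlier compounds showed that this position is sensitive only through exchanges of whole groups, whereas the new result adds that phenylsulfanyl is better placed than 3-nitrophenyl, a 7.0-fold lower number from compound 2 to compound 4 (0.85 log units; beyond the scatter), but still does not reach thiophen-2-yl, a 50-fold higher number from compound 1 to compound 4 (1.70 log units; beyond the scatter); the two groups containing sulfur therefore give the two lowest numbers among these four compounds, although the sulfur sits in a linker in one and in a ring in the other. No supporting data on the origin of the oxygen-to-sulfur difference are available here.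

The compounds shown leave open whether the link atom itself sets the number, which a phenylamino group with its nitrogen link, a benzyl group with its methylene link or an unsubstituted phenyl group joined directly to the core would help to test. Also open, from the compounds shown here alone, is whether the thiophen-2-yl result depends on that ring or extends to a furan-2-yl group, and whether a thiophen-2-ylsulfanyl group would combine the two best features seen so far.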